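Extending the Ethyl Side Chain at the Shared Core

A few compounds are considered here, and "the series" means these few. Any claim that something is new, unique, unknown or untested is made for them only; others in the source may bear on it.

Compound 1 `CCC1(CCCCN2CCN(c3cccc(Cl)c3)CC2)C(=O)Nc2ccccc21` is the reference point of this small set. In an assay on CHO cells for displacement of a labelled ligand from 5-hydroxytryptamine receptor 7 (Homo sapiens) (a lower number here means a stronger inhibitor, a higher number a weaker inhibitor), compound 1 gives 0.41 nM, the lowest of the two numbers recorded. Within the data shown here, its only measured neighbour is compound 2 `CCC1(CCCCN2CCN(c3ccccc3)CC2)C(=O)Nc2ccccc21`, which in this assay gives 2.07 nM; the step of a 5.0-fold higher number from compound 1 to compound 2 (0.70 log units; beyond the scatter) describes the replacement of the chloro group on the aromatic ring by hydrogen.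

Compound 3 `CC(C)CC1(CCCCN2CCN(c3cccc(Cl)c3)CC2)C(=O)Nc2ccccc21` has not been measured. It differs from compound 1 by isopropyl in place of methyl on a saturated chain carbon bound to a saturated ring carbon. Among the measured compounds shown here, none of the measured steps touches this part of the molecule: the single step between compound 1 and compound 2 concerns the aromatic ring, not the saturated chain carbon, so it offers no direct guide to the size or direction of the change to compound 3.

For the measured compounds named here, with no directly comparable step, a modest weakening is estimated rather than a change beyond the scatter of any clear size, and compound 3 is expected to give 1.2 nM in this assay, within the range 0.3 nM to 5 nM, a step of a 2.9-fold higher number from compound 1 to compound 3 (0.47 log units; beyond the scatter).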

Compound 3, inhibition constant: 1.8 nM
Beside the measured number, compound 3's estimate is 1.5-fold (0.18 log units) below it; low and high end bracket the measured number.
By their numbers in this assay, from the lowest: compound 1; then compounds 3 and 2 (each within the scatter of the next).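

Among these compounds, this is the first measured change at the saturated chain carbon bound to a saturated ring carbon, and in this assay going from ethyl to isobutyl gives a 4.4-fold higher number from compound 1 to compound 3 (0.64 log units; beyond the scatter), so the number responds to this side chain as well as to the chloro group on the aromatic ring. With its steps to both measured neighbours beyond the scatter, compound 1 remains the strongest of the set, and its ethyl side chain is the better of the two side chains compared here, though a single change at this position establishes no trend with chain size or branching. No measured information on the origin of this change is available here, so the data show its size and direction but offer no explanation for it.

The compounds shown leave open whether the straight n-propyl or n-butyl chain, or a ring-bearing group such as benzyl, would behave like isobutyl at this position. They also leave open whether the effect of isobutyl would be the same on a core carrying hydrogen in place of the chloro group.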